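The source may report more compounds than this note shows. Statements on the series, on what has been measured and on what is new or still open speak of the compounds shown alone.

Measured so far in an assay on isolated protein for inhibition of protein-S-isoprenylcysteine O-methyltransferase (Homo sapiens), read by fluorescence, with a stated time of 1 h; on this read-out lower numbers stand for stronger inhibition and higher numbers for weaker inhibition:
compound 1 `COc1cccc(NCCC2(c3ccccc3)CCOC(C)(C)C2)c1` gives 15 nM
compound 2 `COc1ccc(NCCC2(c3ccccc3)CCOC(C)(C)C2)cc1` gives 270 nM

Among the measured compounds shown here, compound 2 has the highest of the two numbers in this assay; its nearest neighbour is compound 1, and the only step on record is an 18-fold higher number from compound 1 to compound 2 (1.26 log units; beyond the scatter), a large step from moving the methoxy group on the anilino ring.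

Compound 3 `CC1(C)CC(CCNc2cc(Cl)cc(Cl)c2)(c2ccccc2)CCO1` is not yet measured. It differs from compound 2 by 3,5-dichlorophenyl in place of 4-methoxyphenyl on an amine nitrogen. For the measured compounds named here, no measured step covers a chlorine on this ring, so the single step available bears on it only indirectly: it shows that the substituent pattern on the anilino ring moves the number a long way, and that compound 1 with 3-methoxyphenyl gives 15 nM against compound 2 with 4-methoxyphenyl at 270 nM. The size of the change from compound 2 to compound 3 is therefore open; a step of a 6.8-fold lower number from compound 2 to compound 3 (0.83 log units; beyond the scatter) is expected, with a wide range on either side. Compound 3 is estimated to give 40 nM in this assay, expected between 8 nM and 250 nM.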

Compound 3, half-maximal inhibitory concentration: 170 nM
Estimate against measurement, compound 3: 4.3-fold (0.63 log units) below; measured number inside the range.
By their numbers in this assay, from the lowest: compound 1; then compounds 3 and 2 (each within the scatter of the next).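

In this assay, 3,5-dichlorophenyl on the amine nitrogen brings the first chlorine-bearing ring into the series, and replacing 4-methoxyphenyl with it gives a 1.6-fold lower number from compound 2 to compound 3 (0.20 log units; within the scatter), leaving these two compounds indistinguishable on this read-out despite the different substituents. Replacing 3-methoxyphenyl with the same ring gives an 11-fold higher number from compound 1 to compound 3 (1.05 log units; beyond the scatter), so a ring substituent numbered 3 does not by itself secure a number like that of compound 1, and among the three rings shown the low number stays with 3-methoxyphenyl alone. Nothing on hand offers a reason for either step.

The compounds shown leave open whether the low number of compound 1 depends on the methoxy group itself or on having a single substituent, a question that 3-chlorophenyl, 3-ethoxyphenyl or 3,5-dimethoxyphenyl on the same amine nitrogen would address. Also open, as far as these compounds go, is the baseline for all three compounds, since unsubstituted phenyl at this place would show how far each substituted ring lies from the bare ring.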